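Bromoquinazoline series: swapping the styryl aryl group

The source may report more compounds than this note shows. Statements on the series, on what has been measured and on what is new or still open speak of the compounds shown alone.

Compound 2 `O=S(=O)(/C=C/c1ccc(Br)cc1)Cc1ccc(Nc2ncnc3ccc(Br)cc23)cc1` in a functional assay on OVCAR-8 cells (Homo sapiens) (a higher number here means a weaker inhibitor of growth, a lower number a stronger inhibitor of growth), gives 2000 nM. Compound 1 `O=S(=O)(/C=C/c1ccc(Cl)cc1Cl)Cc1ccc(Nc2ncnc3ccccc23)cc1` differs from it in two places, and in this assay compound 1 gives 4000 nM; the two numbers lie within the usual scatter of each other, so the pair shows no difference that can be read. Compound 3 `O=S(=O)(/C=C/c1ccc(Cl)cc1Cl)Cc1ccc(Nc2ncnc3ccc(Br)cc23)cc1` changes compound 2 only at the chain: 2,4-dichlorophenyl in place of 4-bromophenyl on a double-bonded chain carbon bound to a double-bonded chain carbon. Among the measured compounds shown here, with no measured step to lean on, the expected move a 1.5-fold higher number from compound 2 to compound 3 (0.18 log units; within the scatter) is none beyond the scatter. The estimate for compound 3 in this assay is therefore 3000 nM, between 1500 nM and 6000 nM.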

Compound 3, concentration for 50% growth inhibition: 3000 nM
Estimate against measurement, compound 3: no gap at the digits printed; low and high end bracket the measured number.
By their numbers in this assay, from the lowest: compounds 2, 3 and 1 (each within the scatter of the next).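

In this assay, 2,4-dichlorophenyl in place of 4-bromophenyl on the chain gives no readable difference (a 1.5-fold higher number from compound 2 to compound 3 (0.18 log units; within the scatter)). Bromo in place of hydrogen on an aromatic carbon also gives none (a 1.3-fold lower number from compound 1 to compound 3 (0.12 log units; within the scatter)). Compound 3 thus separates the two changes of the earlier pair, and neither single change stands out from the scatter. Still open, from the compounds shown here alone, is whether a non-aryl group at this chain carbon, such as an amine or a carboxylic acid, would shift the number beyond the scatter. No supporting data bear on this result.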